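A few compounds are considered here, and "the series" means these few. Any claim that something is new, unique, unknown or untested is made for them only; others in the source may bear on it.

Measured so far:
compound 1 `CCCCCCCCCCCCCCCOC1(c2ccc(Cl)cc2)SC=C(C)n2c1noc2=O`: > 100000 nM
compound 2 `CCCCOC1(c2ccc(Cl)cc2)SC=C(C)n2c1noc2=O`: 89000 nM
compound 3 `CCCCCCCCCCCCCCCCCCOC1(c2ccc(Cl)cc2)SC=C(C)n2c1noc2=O`: > 100000 nM

All three share one core and differ only in the chain on the ether oxygen. They were tested in a functional assay on A2780 cells (Homo sapiens) for antiproliferative activity, read by MTT assay, with a stated time of 3 days; a lower number here means a stronger inhibitor, a higher number a weaker inhibitor. For compound 1 the value > 100000 nM is a limit of the assay, not a number. For compound 3 the value > 100000 nM is likewise a limit. Only compound 2 gives a number, 89000 nM. The step from compound 3 to compound 1 cannot be read, a step that the two limits leave unreadable from compound 3 to compound 1, because of the limit of > 100000 nM in this assay, at which 2 of the 3 values shown sit. Shortening the chain further gives an at least 1.1-fold lower number from compound 1 to compound 2 (0.05 log units; that floor lies within the scatter). How compound 2 and compound 3 differ is not broken down here.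

Compound 4 `COC1(c2ccc(Cl)cc2)SC=C(C)n2c1noc2=O` is the next shorter chain, (hydrogen in place of propyl on a saturated chain carbon bound to an oxygen on a saturated carbon). The same kind of change, though at a different place along the chain, is hydrogen in place of propyl on a saturated chain carbon, ten or more bonds along the chain from an oxygen on a saturated carbon, whose step stayed unreadable. With only the small step to compound 2 to lean on, compound 4 is expected to move little, a 1.0-fold lower number from compound 2 to compound 4 (0.02 log units; within the scatter). Compound 4 is therefore estimated at 85000 nM, between 35000 nM and 200000 nM.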

Compound 4, half-maximal inhibitory concentration: 166000 nM
Beside the measured number, compound 4's estimate is 2.0-fold (0.29 log units) below it; low and high end bracket the measured number.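

In this assay, putting hydrogen in place of propyl, which turns butoxy into methoxy, gives a 1.9-fold higher number from compound 2 to compound 4 (0.27 log units; within the scatter). On this evidence, the change makes no clear difference on this one core, but all the compounds shown share that core, so nothing here tests whether the same change would behave alike on a different one. The steps among the longer chains cannot be read, so they offer no second case of the change to compare with this one: the limit of > 100000 nM in this assay, at which 2 of the 4 values shown sit.

Still open, going by these compounds, is how butoxy and methoxy would compare on another core, and whether a step of this kind would then rise clearly beyond the scatter. Also open, on these data alone, is whether an ether chain carrying an amine or a carboxylic acid would give a number clearly different from those of compound 2 and compound 4.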